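Lipophilicity of Quinoline Ether Amides: A Pyridyl Replacement

The source may report more compounds than this note shows. Statements on the series, on what has been measured and on what is new or still open speak of the compounds shown alone.

Measured compounds:
- Compound 1 `Cc1cc(C)cc(NC(=O)COc2cc(C)nc3ccc(C(F)(F)F)cc23)c1`: 6.67
- Compound 2 `COc1ccc(NC(=O)COc2cc(C)nc3ccc(OC)cc23)cc1`: 4.22
- Compound 3 `COc1ccc2nc(C)cc(OCC(=O)Nc3cc(OC)c(OC)c(OC)c3)c2c1`: 3.95

Of the compounds shown here, three built on a shared core have been measured in a physicochemical assay for lipophilicity, read by HPLC, in phosphate buffer, measured as chromatographic lipophilicity, at pH 7.4; a higher number here means a more lipophilic compound, a lower number a more polar compound. Compound 1 gives 6.67, which is the highest number in the set. Compound 2 gives 4.22, the second highest of the three; its nearest neighbour is compound 3, which gives 3.95. The gap between compound 2 and compound 3 falls within the scatter of repeated measurements, so no order between those two can be claimed, whereas compound 1 stands clearly apart from both.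

Compound 4 `COc1ccc2nc(C)cc(OCC(=O)Nc3c(C)cncc3C)c2c1` has not yet been measured in this assay. It differs from compound 2 in one place: 3,5-dimethylpyridin-4-yl in place of 4-methoxyphenyl on an amide-type nitrogen. For the measured compounds named here, no measured pair of compounds shows this particular change, so its effect can only be estimated. The expectation is a moderate move downward from the value of compound 2, a step from compound 2 to compound 4 of about a number 0.62 log units lower from compound 2 to compound 4 (beyond the scatter), which would take it beyond the usual scatter. Compound 4 is therefore expected to give roughly 3.6 in this assay, with a plausible range from 2.9 to 4.3.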

Compound 4, distribution coefficient: 3.01
Compound 4: the middle estimate sits 0.59 log units above what was measured; the measured number falls inside the stated range.
By their numbers in this assay, from the lowest: compound 4; then compounds 3 and 2 (each within the scatter of the next); then compound 1.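

In this assay, for the compounds shown here, putting 3,5-dimethylpyridin-4-yl in place of 4-methoxyphenyl on the amide-type nitrogen gives a number 1.21 log units lower from compound 2 to compound 4 (beyond the scatter), the first measured one-place change in this set. The two groups match in several computed counts: each has 8 heavy atoms, 7 of them carbon, the same numbers of hydrogen-bond donors and acceptors, and no net charge. Even so, a swap that leaves those counts unchanged moves the number well beyond the scatter, so these counts alone do not capture what matters at this position, and nothing measured here explains the size of the step.

This swap adds a ring nitrogen, removes the methoxy group and adds two methyl groups all at once, so the compounds shown leave open how much of the step belongs to each of these changes; a plain pyridin-4-yl on the same amide-type nitrogen would help to separate them. Going by these compounds alone, with only this one pair, it also remains open whether the same swap would give a step of similar size on a different core, such as that of compound 1.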